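Replacing methoxy with nitro in compound 3

This account rests on a few compounds, and the source may have more. Where it says the series, first, only, none or still open, it means among the compounds named here.

Compound 1 `COc1ccc(-c2noc(CCCCCCC(=O)NO)n2)cc1` gives 20400 nM 
Compound 2 `O=C(CCCCCCc1nc(-c2ccc(F)cc2)no1)NO` gives 19400 nM 
Compound 3 `COc1ccc(-c2noc(CCCCCCC(=O)C(F)(F)F)n2)cc1` gives 5050 nM 

In a functional assay on NCI-H661 cells (Homo sapiens) for antiproliferative activity, read by MTT assay, with a stated time of 72 h (on this read-out lower numbers stand for stronger inhibition and higher numbers for weaker inhibition), compound 3 stands lowest of these three numbers. Trifluoromethyl in place of hydroxyamino on a carbonyl carbon gave a 4.0-fold lower number from compound 1 to compound 3 (0.61 log units; beyond the scatter), a modest step that is beyond the scatter. Compound 4 `O=C(CCCCCCc1nc(-c2ccc([N+](=O)[O-])cc2)no1)C(F)(F)F` keeps that trifluoromethyl and carries nitro in place of methoxy on an aromatic carbon, para to a large group: nitro in place of methoxy on an aromatic carbon. Within the data shown here, no measured compound carries nitro, so the evidence is indirect. The nearest measured change is fluoro in place of methoxy on an aromatic carbon, which gave a 1.1-fold lower number from compound 1 to compound 2 (0.02 log units; within the scatter), a step within the scatter. That change was measured with hydroxyamino rather than trifluoromethyl on the carbonyl carbon. Among the measured compounds shown here, with compound 2 at 19400 nM as the only guide, no step beyond the scatter is expected in this assay. The estimated change is a 1.0-fold lower number from compound 3 to compound 4 (0.00 log units; within the scatter), with wide uncertainty. For compound 4 the expected value is 5000 nM, within an estimated range from 2000 nM to 12000 nM.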

Compound 4, half-maximal inhibitory concentration: 17500 nM
For compound 4 the middle estimate is 3.5-fold (0.54 log units) below the measured one; the measured number lies above the stated range.
By their numbers in this assay, from the lowest: compound 3; then compounds 4, 2 and 1 (each within the scatter of the next).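

In this assay the aromatic carbon para to a large group proves sensitive to what it carries: nitro in place of methoxy gave a 3.5-fold higher number from compound 3 to compound 4 (0.54 log units; beyond the scatter) and so weaker inhibition, a modest step but one beyond the scatter. The earlier change at this carbon, fluoro in place of methoxy with hydroxyamino on the carbonyl carbon, gave a 1.1-fold lower number from compound 1 to compound 2 (0.02 log units; within the scatter) and stayed within the scatter, so only now does a replacement of methoxy here register. Nothing available explains this loss.

As far as these compounds go, it remains open whether nitro would shift the number in the same way with hydroxyamino on the carbonyl carbon, and whether fluoro would leave it unchanged with trifluoromethyl there. Also open, from the compounds shown here alone, is how an amine or a carboxylic acid on this aromatic carbon would compare with methoxy and nitro.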